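A few compounds are considered here, and "the series" means these few. Any claim that something is new, unique, unknown or untested is made for them only; others in the source may bear on it.

Compound 2 `C=CC(=O)Nc1cccc(NC(=O)CSc2nc(Nc3cccc(C)c3)c3ccccc3n2)c1` is, in a functional assay on PC-3 cells (Homo sapiens) for inhibition, read by MTT assay, with a stated time of 72 h (a lower number here means a stronger inhibitor, a higher number a weaker inhibitor), the higher of the two numbers recorded, at 29200 nM; its nearest neighbour is compound 1 `C=CC(=O)Nc1cccc(NC(=O)CSc2nc(Nc3ccccc3C)c3ccccc3n2)c1`, which in this assay gives 23200 nM. Going by the values given here, the only measured step, a 1.3-fold higher number from compound 1 to compound 2 (0.10 log units; within the scatter), lies within the scatter, so the two aryl groups on the nitrogen on the aromatic ring cannot be told apart on these data. Compound 3 `C=CC(=O)Nc1cccc(NC(=O)CSc2nc(Nc3ccc(F)cc3)c3ccccc3n2)c1` differs from compound 2 by 4-fluorophenyl in place of 3-methylphenyl on a nitrogen on an aromatic ring. Among the compounds with values here, no measured step touches a fluorine on that ring, so the expectation rests only on the finding that moving a methyl around the same ring left the number unchanged within the scatter; a step of similar small size, with no clear direction, is therefore expected, a 1.1-fold lower number from compound 2 to compound 3 (0.05 log units; within the scatter). On that basis compound 3 is estimated in this assay at 26000 nM, with a range from 8000 nM to 85000 nM.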

Compound 3, half-maximal inhibitory concentration: 8240 nM
Compound 3: the middle estimate sits 3.2-fold (0.50 log units) above what was measured, and the stated range covers the measured number.
By their numbers in this assay, from the lowest: compound 3; then compounds 1 and 2 (each within the scatter of the next).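

In this assay the aryl group on the nitrogen on an aromatic ring now makes a difference beyond the scatter, with 4-fluorophenyl in place of 3-methylphenyl (a 3.5-fold lower number from compound 2 to compound 3 (0.55 log units; beyond the scatter)) and in place of 2-methylphenyl (a 2.8-fold lower number from compound 1 to compound 3 (0.45 log units; beyond the scatter)). The two methylphenyl groups could not be told apart, but compound 3 gives the lowest number of the three, so this position does respond to a change of aryl group, though only modestly. Nothing given here accounts for that step.

From the compounds shown here alone, in these compounds the methyl and the fluorine never share a place on the ring, and it stays open whether the step belongs to the fluorine itself or to its place. A methoxy group, a chlorine or an amine on that ring also remains an open case.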